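Fluoro for hydrogen: from compound 2 to compound 4

The source may hold more compounds than are shown below. What is called first, only, known or untested is meant among the compounds shown, and "the series" means these compounds.

Measured compounds:
compound 1 `COc1ccc(/C=C/C=C/C(=O)c2cc(Cl)ccc2O)cc1` — "not active" (no number reported)
compound 2 `COc1ccc(/C=C/C=C/C(=O)c2ccccc2O)cc1` — 40%
compound 3 `O=C(/C=C/C=C/c1ccccc1)c1ccccc1O` — "not active" (no number reported)

Within the data shown here, in an in vitro assay on cells for inhibition of Amine oxidase [flavin-containing] A (Homo sapiens), read by Amplex Red, with a stated time of 15 min, tested at 100 uM (on this read-out lower numbers stand for less inhibition and higher numbers for more inhibition at the one concentration tested (going by the name of the read-out)), compound 2 gives 40%, the only number in the set. Compound 1 is reported in this assay as "not active" (no number reported) without a figure. Compound 3 is likewise reported in this assay as "not active" (no number reported) without a figure. Among the measured compounds shown here, no pair of these three is separated by a single change, so no step between measured compounds can be stated; compound 2 is simply the one entry with a number, and the other two entries carry only the reported verdict without a number.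

Compound 4 `COc1ccc(/C=C/C=C/C(=O)c2cc(F)ccc2O)cc1` differs from compound 2 by fluoro in place of hydrogen on an aromatic carbon. With the rest of the structure unchanged, the expectation rests on compound 2 alone, since the two entries reported without a number give no measurable direction. The expected step of a number 12 percentage points lower from compound 2 to compound 4 (beyond the scatter) is a modest fall, at the edge of the scatter rather than clearly beyond it, with a real chance that compound 4 is returned without a number. Compound 4 is estimated at 28%, within 5% to 50%.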

Compound 4, a percentage reported as inhibition, at one concentration (the size of the read-out at that concentration, not a potency): "not active" (no number reported)
The entry for compound 4 holds no number, so the estimate cannot be set against anything.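

Compound 4 carries no number, so no step from compound 2 to compound 4 can be read, and no measurement bears on a cause. The compounds shown leave open how large any change with fluoro in place of hydrogen is, and where compound 1 and compound 3 stand numerically.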